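The compounds below may be only part of what the source reports. "The series", "measured", "known", "first", "only" and "open" are said of these compounds alone.

Measured compounds:
Compound 1 `CCCNc1nc2cc(-c3ccc(C)cc3)sc2c(=O)[nH]1` — in an ADME assay on HepG2 cells (Homo sapiens) for cytotoxicity, read by MTT assay, with a stated time of 72 h (on this read-out higher numbers stand for lower toxicity in this test and lower numbers for higher toxicity in this test), compound 1 gives a value that is a limit of the assay, > 62500 nM.
Compound 2 `Cc1ccc(-c2cc3nc(NCC(C)C)[nH]c(=O)c3s2)cc1` — in this assay compound 2 gives 21600 nM.
Compound 3 `CC(C)(C)Nc1nc2ccsc2c(=O)[nH]1` — in this assay compound 3 gives 8400 nM.

Compound 4 `CC(C)Nc1nc2ccsc2c(=O)[nH]1` is not yet measured. It differs from compound 3 by hydrogen in place of methyl on a saturated chain carbon bound to a nitrogen on an aromatic ring and two saturated chain carbons. The same kind of change, (hydrogen in place of methyl on a saturated chain carbon bound to two saturated chain carbons), links the measured pair and gave an at least 2.8-fold higher number from compound 2 to compound 1 (0.46 log units; beyond the scatter), though that step only sets a floor, since compound 1 sits at the limit of > 62500 nM in this assay, at which 1 of the 3 values shown sits. The two places are not the same word for word: in compound 3 the carbon is bound to a nitrogen on an aromatic ring and two saturated chain carbons, in compound 2 only to two saturated chain carbons. The difference between the core of compound 3 and that of compound 2 is not broken down here.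

For compound 4 a step of a 2.4-fold higher number from compound 3 to compound 4 (0.38 log units; beyond the scatter) in this assay is expected, resting on the measured step from compound 2 to compound 1, an at least 2.8-fold higher number from compound 2 to compound 1 (0.46 log units; beyond the scatter), and on the value of compound 3, 8400 nM. Compound 4 is estimated at 20000 nM, between 8000 nM and 62500 nM.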

Compound 4, half-maximal cytotoxic concentration: 23900 nM
Compound 4: middle estimate off by 1.2-fold (0.08 log units), on the low side, within the range that was stated.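

In this assay, hydrogen in place of methyl on the saturated chain carbon bound to a nitrogen on an aromatic ring and two saturated chain carbons, tert-butyl to isopropyl, gives a 2.8-fold higher number from compound 3 to compound 4 (0.45 log units; beyond the scatter). The change thus runs the same way on two cores, but two pairs say nothing about further cores, and the carbon carrying the change has different neighbours in each pair: the same change on two cores in this assay, an at least 2.8-fold higher number (0.46 log units; beyond the scatter) from compound 2 to compound 1 and a 2.8-fold higher number (0.45 log units; beyond the scatter) from compound 3 to compound 4; the limit leaves it open whether they differ Compound 1 gives > 62500 nM, a limit of the assay.

Still open, going by these compounds, is what a longer chain or a carboxylic acid in place of the isopropyl group would give in this assay. Also open, on these data alone, is whether the same change holds on a third core.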